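A few compounds are considered here, and "the series" means these few. Any claim that something is new, unique, unknown or untested is made for them only; others in the source may bear on it.

Among the measured compounds shown here, compound 2, drawn as `O=C(O)/C=C/C(=O)c1ccc(F)cc1`, carries a fluoro group on its benzene-bearing core and is one of three compounds tested so far in a functional assay on HeLa cells (Homo sapiens) for inhibition, read by MTT assay, with a stated time of 72 h (a lower number here means a stronger inhibitor, a higher number a weaker inhibitor), where compound 2 gives 28400 nM. That is the highest of the three numbers. The nearest companion is compound 3, `CCc1c(C(=O)/C=C/C(=O)O)cc(C(C)C)cc1C(C)C`, which in this assay gives 7610 nM, and the furthest is compound 1, `CCc1cc(CC)c(C(=O)/C=C/C(=O)O)c(CC)c1`, which in this assay gives 6530 nM. Both of those alkyl-substituted compounds sit beyond the scatter from compound 2, so compound 2 is the weakest inhibitor of the measured set.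

The next compound, compound 4, is `CC(C)(C)c1ccc(C(=O)/C=C/C(=O)O)cc1`. Its structural difference from compound 2 is tert-butyl in place of fluoro on an aromatic carbon, para to a group of 7 heavy atoms. For the measured compounds named here, no single-change step between measured compounds is available, so any expectation rests on the whole set. Since compounds 1 and 3, each with alkyl substitution on the aromatic ring, give lower numbers than compound 2, a step toward a lower number is expected, of moderate size and beyond the scatter. Compound 4 is therefore estimated at 10000 nM, within a range from 4000 nM to 25000 nM, which means an expected step of a 2.8-fold lower number from compound 2 to compound 4 (0.45 log units; beyond the scatter).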

Compound 4, half-maximal inhibitory concentration: 5100 nM
Estimate against measurement, compound 4: 2.0-fold (0.29 log units) above; the measured number falls inside the stated range.
By their numbers in this assay, from the lowest: compounds 4, 1 and 3 (each within the scatter of the next); then compound 2.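

Among the compounds shown here, the exchange of fluoro for tert-butyl on an aromatic carbon, para to a group of 7 heavy atoms, gives in this assay the first step in this set that can be read at a single place, a 5.6-fold lower number from compound 2 to compound 4 (0.75 log units; beyond the scatter), and it is beyond the scatter. The earlier compounds shown here differ from one another in more than one place, so they could not tie a change in the number to one group; this pair shows that the number responds to the group at this position, as 4 heavy atoms enter where 1 leaves and neither group has a hydrogen-bond donor or acceptor. No measurement is available that accounts for this step.

With only fluoro and tert-butyl shown at this carbon, the compounds leave open how a methyl, an isopropyl, a methoxy or an amine group would read there, and whether the number follows the count of heavy atoms at all. They also leave open whether the same exchange would give a step of similar size on the more heavily alkylated cores of compound 1 and compound 3.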